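A few compounds are considered here, and "the series" means these few. Any claim that something is new, unique, unknown or untested is made for them only; others in the source may bear on it.

In a functional assay on HEK293 cells (Homo sapiens) for cytotoxicity (a higher number here means that more compound is tolerated, a lower number that less compound is tolerated), the values are these, each a limit and not a number:

- Compound 1 `COc1ccc([C@H]2CC(=O)N(c3cccc(O)c3)C2)cc1OC1CCCC1` gives > 10000 nM
- Compound 2 `COc1ccc([C@H]2CC(=O)N(c3ccccc3N)C2)cc1OC1CCCC1` gives > 10000 nM
- Compound 3 `COc1ccc([C@H]2CC(=O)N(c3ccc(N)cc3)C2)cc1OC1CCCC1` gives > 10000 nM

Compound 3 thus stands at a limit and has no number, like the other two: the limit of > 10000 nM in this assay, at which 3 of the 3 values shown sit. In compound 4 `COc1ccc([C@H]2CC(=O)N(c3cccc(C)c3)C2)cc1OC1CCCC1`, 3-methylphenyl stands in place of 4-aminophenyl on an amide-type nitrogen in a ring: 3-methylphenyl in place of 4-aminophenyl on an amide-type nitrogen in a ring. Three measured steps change the group at this place: a step that the two limits leave unreadable from compound 1 to compound 2, a step that the two limits leave unreadable from compound 1 to compound 3 and a step that the two limits leave unreadable from compound 2 to compound 3. None has a readable size, and all three compounds stay at the limit. No step beyond the scatter is therefore expected in this assay, and compound 4 will probably report a limit too. The expected step is a step that the limit leaves unreadable from compound 3 to compound 4, with no direction favoured. Compound 4 is estimated at 12000 nM, with an expected range from 6000 nM to 30000 nM.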

Compound 4, half-maximal cytotoxic concentration: > 10000 nM
Compound 4 was reported as a limit (the forecaster's own chance of this, stated with the estimate: 90%); the middle value does not contradict the limit.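

Compound 4 reports only a limit in this assay, so its steps from compound 1, compound 2 and compound 3 cannot be read: the limit of > 10000 nM in this assay, at which 4 of the 4 values shown sit.

The compounds shown leave open at what concentration any of them becomes cytotoxic in this assay, and whether the groups compared differ there at all.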